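Amide nitrogen swaps on a diaryl aminothiophene core

The source may hold more compounds than are shown below. What is called first, only, known or untested is meant among the compounds shown, and "the series" means these compounds.

Measured in a functional assay on A549 cells (Homo sapiens) for inhibition, read by sulforhodamine B assay, with a stated time of 72 h; a higher number here means a weaker inhibitor, a lower number a stronger inhibitor:
- compound 1, `Nc1sc(-c2ccc(Cl)cc2)c(-c2ccc(Cl)cc2)c1C(=O)NC1CCC(O)CC1`, gives 250 nM
- compound 2, `CC(C)(C)NC(=O)c1c(N)sc(-c2ccc(Cl)cc2)c1-c1ccc(Cl)cc1`, gives 8850 nM
- compound 3, `Nc1sc(-c2ccc(Cl)cc2)c(-c2ccc(Cl)cc2)c1C(=O)NC1CCCCC1`, gives 2410 nM

Compound 2 stands at the top of the three numbers, the weakest inhibitor in this assay; its nearest neighbour is compound 3, as a 3.7-fold lower number from compound 2 to compound 3 (0.56 log units; beyond the scatter) shows, and compound 1 lies furthest away, as a 35-fold higher number from compound 1 to compound 2 (1.55 log units; beyond the scatter) shows. Compound 4, `Nc1sc(-c2ccc(Cl)cc2)c(-c2ccc(Cl)cc2)c1C(=O)N1CCC(=O)CC1=O`, is not yet measured. It differs from compound 2 at the amide-type nitrogen: 2,4-dioxopiperidin-1-yl in place of (tert-butyl)amino on a carbonyl carbon. Both measured steps concern this same position. The hydroxy group on the saturated ring in compound 1 matters, as a 9.6-fold higher number from compound 1 to compound 3 (0.98 log units; beyond the scatter) shows, and a ring in place of the open tert-butyl group helped moderately, as a 3.7-fold lower number from compound 2 to compound 3 (0.56 log units; beyond the scatter) shows. For the measured compounds named here, compound 4 brings a ring and two acceptors but loses the only donor, a change no measured step covers. A modest gain is therefore expected for compound 4, estimated as a 1.8-fold lower number from compound 2 to compound 4 (0.25 log units; within the scatter), giving an expected 5000 nM with a range from 1000 nM to 30000 nM in this assay.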

Compound 4, half-maximal inhibitory concentration: 4090 nM
The estimate for compound 4 lay 1.2-fold (0.09 log units) above the measured number; measured number inside the range.
By their numbers in this assay, from the lowest: compound 1; then compounds 3 and 4 (each within the scatter of the next); then compound 2.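

In this assay, the 2,4-dioxopiperidin-1-yl group, with 0 hydrogen-bond donors, still gives a lower number than the open (tert-butyl)amino group (a 2.2-fold lower number from compound 2 to compound 4 (0.34 log units; beyond the scatter)), so among these compounds a donor at this place is not needed to improve on compound 2. Against the cyclohexylamino group, the same ring cannot be told apart (a 1.7-fold higher number from compound 3 to compound 4 (0.23 log units; within the scatter)), even though it carries 2 hydrogen-bond acceptors. Its two carbonyl oxygens do not match the (4-hydroxycyclohexyl)amino group, which remains clearly ahead (a 16-fold higher number from compound 1 to compound 4 (1.21 log units; beyond the scatter)). Nothing available here explains why these groups differ. Still open, going by these compounds, is whether an amine or a carboxylic acid on the cyclohexyl ring, in place of the hydroxy group, would bring the number as low as that of compound 1.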